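The source may hold more compounds than are shown below. What is called first, only, known or untested is meant among the compounds shown, and "the series" means these compounds.

Measured so far:
compound 1, `C#Cc1ccccc1-c1c(C#N)c(-c2ccc(CC)cc2)nc2c1c(C)nn2-c1ccccc1`, > 20000 nM
compound 2, `CCCc1ccc(-c2nc3c(c(C)nn3-c3ccccc3)c(-c3ccccc3O)c2C#N)cc1`, 22500 nM

For the measured compounds named here, in an ADME assay on BJ cells (Homo sapiens) for cytotoxicity, with a stated time of 72 h (on this read-out higher numbers stand for an effect only at larger amounts of compound and lower numbers for an effect already at smaller amounts), compound 2 gives 22500 nM, the only plain number in the set. For compound 1 the result of > 20000 nM is a limit of the assay, not a number; it sits at the limit of > 20000 nM in this assay, at which 1 of the 2 values shown sits. Going by the values given here, no step between measured compounds is available. Compound 3 `Cc1nn(-c2ccccc2)c2nc(-c3ccc4c(c3)OCCO4)c(C#N)c(-c3ccccc3O)c12` differs from compound 2 by 2,3-dihydro-1,4-benzodioxin-6-yl in place of 4-propylphenyl on an aromatic carbon. No shift beyond the usual scatter is expected, so the step of a 1.1-fold lower number from compound 2 to compound 3 (0.05 log units; within the scatter) is estimated as flat. Compound 3 is therefore expected to give 20000 nM, between 8000 nM and 60000 nM, with a fair chance that this assay again reports only a limit.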

Compound 3, half-maximal effective concentration: > 20000 nM
Compound 3 ended at the assay's limit (the forecaster's own chance of this, stated with the estimate: 50%); the middle value lies on the limit itself.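

For the compounds shown here, compound 3 gives > 20000 nM, a limit of the assay and not a number, so no step from compound 2 to compound 3 can be read. The compounds shown leave open how 2,3-dihydro-1,4-benzodioxin-6-yl and 4-propylphenyl actually compare at this place.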